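Hydroxy for chloro on the nitro-styryl cyclohexanone series

The source may report more compounds than this note shows. Statements on the series, on what has been measured and on what is new or still open speak of the compounds shown alone.

Among the measured compounds shown here, compound 2 `O=C1/C(=C/c2ccc(Cl)cc2)CCC/C1=C\c1ccc([N+](=O)[O-])cc1` is the only member of the series with a number in a functional assay on HPC cells (Homo sapiens) for cytotoxicity; a higher number here means that more compound is tolerated, a lower number that less compound is tolerated; there compound 2 gives 345000 nM. Compound 1 `COc1cc(/C=C2\CCC/C(=C\c3ccc([N+](=O)[O-])cc3)C2=O)ccc1O` sits at a limit of this assay, > 400000 nM, and is a limit rather than a number. For the measured compounds named here, the one measured step, an at least 1.1-fold lower number from compound 1 to compound 2 (0.06 log units; that floor lies within the scatter), is the only comparison available, and the limit of > 400000 nM in this assay, at which 1 of the 2 values shown sits, means it can be read only as a floor.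

Compound 3 `O=C1/C(=C/c2ccc(O)cc2)CCC/C1=C\c1ccc([N+](=O)[O-])cc1` differs from compound 2 in one place: hydroxy in place of chloro on an aromatic carbon. This change partly retraces the measured step, since a hydroxy group enters on the same aromatic carbon of a six-membered aromatic ring of carbon only, para to a large group, where compound 1 also carries a hydroxy. Given that the step from compound 1 to compound 2 is a floor within the scatter, no step beyond the scatter is expected in this assay; if anything, a drift back toward the region of compound 1 is anticipated. The expected step is a 1.2-fold higher number from compound 2 to compound 3 (0.06 log units; within the scatter). For compound 3 the estimate in this assay is 400000 nM, with a range from 200000 nM to 800000 nM.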

Compound 3, half-maximal cytotoxic concentration: > 400000 nM
Compound 3 gave a limit, no number; the forecaster's own chance of this, stated with the estimate: 45%; the middle value lies on the limit itself.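

Among the compounds shown here, the change from 4-chlorophenyl to 4-hydroxyphenyl, made with no methoxy on the ring, gives an at least 1.1-fold higher number from compound 2 to compound 3 (0.06 log units; that floor lies within the scatter) in this assay, so this single change at this position shows no step that can be read as beyond the scatter. In this assay compound 3 gives > 400000 nM, which is a limit and not a number. The step from compound 1 to compound 3, hydrogen in place of methoxy, cannot be read, and the hydroxy-bearing compounds with and without methoxy now rest on the same limit, so that the series offers a single number and otherwise only this ceiling: the limit of > 400000 nM in this assay, at which 2 of the 3 values shown sit.

Still open, as far as these compounds go, is whether any group on this aromatic carbon, such as an amine or a carboxylic acid, would give a step beyond the scatter from compound 2 in this assay. From the compounds shown here alone, how far the hydroxy compounds actually lie from compound 2, and whether methoxy matters at all on the hydroxy-bearing ring, stays unknown while their values remain limits.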